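The compounds below may be only part of what the source reports. "The series", "measured", "known", "first", "only" and "open" are said of these compounds alone.

compound 1 `CCOC(=O)c1ccc(S(N)(=O)=O)cc1` gives 1.17
compound 2 `CCCOC(=O)c1ccc(S(N)(=O)=O)cc1` gives 1.75
compound 3 `CCCCCOC(=O)c1ccc(S(N)(=O)=O)cc1` gives 2.71

In a physicochemical assay for lipophilicity (a higher number here means a more lipophilic compound, a lower number a more polar compound), compound 1 gives 1.17 and stands lowest of the three measured numbers. Compound 4 `CCCCCCOC(=O)c1ccc(S(N)(=O)=O)cc1` has not been measured yet. It differs from compound 1 by butyl in place of hydrogen on a saturated chain carbon, two bonds along the chain from an oxygen next to a carbonyl group.

Going by the values given here, three measured steps bear on this change. Methyl at that same place showed a number 0.58 log units higher from compound 1 to compound 2 (beyond the scatter) and propyl showed a number 1.54 log units higher from compound 1 to compound 3 (beyond the scatter) while ethyl, three bonds along the chain, showed a number 0.96 log units higher from compound 2 to compound 3 (beyond the scatter) with all three beyond the scatter. Among these three compounds the number rises as the chain grows, and none goes against that. Butyl is the next chain up from propyl, so a large upward step in this assay is expected, somewhat larger than the propyl step (a number 2.05 log units higher from compound 1 to compound 4 (beyond the scatter)). For compound 4 the estimated value is 3.22 with an expected range from 2.95 to 3.5 as the likely span.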

Compound 4, partition coefficient: 3.23
Compound 4: the middle estimate sits 0.01 log units below what was measured; measured number inside the range.
By their numbers in this assay, from the lowest: compound 1; then compound 2; then compound 3; then compound 4.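

In this assay the climb does not stop at propyl: butyl at this place gives a number 2.06 log units higher from compound 1 to compound 4 (beyond the scatter), the largest step seen so far. The rise also holds when the comparison starts further up the series, with a number 1.48 log units higher from compound 2 to compound 4 (beyond the scatter) and, for a single added methyl, a number 0.52 log units higher from compound 3 to compound 4 (beyond the scatter), so the number goes up with each longer chain across all four compounds and none goes against that. Nothing available here accounts for this rise.

These compounds leave open whether the climb continues with a heptyl or still longer chain, since the series ends at compound 4. They also leave open what a branched chain such as isopropyl, or a chain carrying an amine or a carboxylic acid, would do at this same place.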